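Adding a Methyl to Two Side Chains on One Core

The source may hold more compounds than are shown below. What is called first, only, known or untested is meant among the compounds shown, and "the series" means these compounds.

Measured compounds and their results:
compound 1 `COC(=O)C1=C(C)N(C)C(=O)NC1c1cccs1`: 15%
compound 2 `CCOC(=O)C1=C(C)N(C)C(=O)NC1c1cccs1`: 2%
compound 3 `CCNC(=O)C1=C(C)NC(=O)NC1c1cccs1`: 4%

All three were tested in an assay on membranes from HeLa cells for displacement of a labelled ligand from adenosine receptor A3 (Homo sapiens), read by scintillation counting, with a stated time of 180 min, tested at 1 uM; a higher number here means more inhibition at the concentration tested (going by the name of the read-out), a lower number less inhibition. Compound 1 reaches 15%, while compound 2 and compound 3 sit near the bottom of the range. Among the compounds with values here, the only one-place change among them is the step from compound 1 to compound 2, (methyl in place of hydrogen on a saturated chain carbon bound to an oxygen next to a carbonyl group), which gave a number 13 percentage points lower from compound 1 to compound 2 (beyond the scatter). Compound 3 differs from compound 1 in more than one place, so the difference between the two cores is not broken down here; its value and that of compound 2 lie within the scatter of each other, and it stands beyond the scatter from compound 1.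

Compound 4 `CC1=C(C(=O)NC(C)C)C(c2cccs2)NC(=O)N1` has not yet been measured in this assay. Relative to compound 3 it carries methyl in place of hydrogen on a saturated chain carbon bound to an amide-type nitrogen and a saturated chain carbon. Within the data shown here, this is the same kind of change as the one from compound 1 to compound 2, a methyl in place of hydrogen, but the place differs: in that pair the carbon is bound to an oxygen next to a carbonyl group, here it is bound to an amide-type nitrogen and a saturated chain carbon. Because a number 13 percentage points lower from compound 1 to compound 2 (beyond the scatter) was lowering, the step from compound 3 to compound 4 is expected to be a number 3 percentage points lower from compound 3 to compound 4 (within the scatter), although compound 3 already sits so low that little room remains. Compound 4 is therefore estimated at 1%, likely between -8% and 10%.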

Compound 4, a percentage reported as inhibition, at one concentration (the size of the read-out at that concentration, not a potency): 1%
Compound 4: middle estimate and measured number agree at the digits printed; measured number inside the range.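

In this assay, the methyl that turns ethylcarbamoyl into isopropylcarbamoyl gives a number 3 percentage points lower from compound 3 to compound 4 (within the scatter), so this step cannot be told apart from no change at all. Set beside the methyl added to the ester side chain, it does not show a measurable difference between the two cores: the same change on two cores in this assay, a number 13 percentage points lower (beyond the scatter) from compound 1 to compound 2 and a number 3 percentage points lower (within the scatter) from compound 3 to compound 4, 10 percentage points apart, within the scatter of two such steps. Within the data shown here, this agrees with the change carrying over from one core to the other, but it does not prove that it does: there are only two pairs, the methyl sits on a carbon bound to an oxygen in one and to an amide-type nitrogen in the other, and compound 3 starts so low that a further drop would have little room to show, while one reading at a single concentration is not a potency.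

The compounds shown leave open whether a longer chain such as butyl, or a cyclopentyl group, on the amide nitrogen would give a clearly higher or lower number than the ethyl and isopropyl groups do. They also leave the ester and the amide unseparated, as compound 1 and compound 3 differ in more than one place, and a pair differing only in that group would be needed to compare them.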